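A few compounds are considered here, and "the series" means these few. Any claim that something is new, unique, unknown or untested is made for them only; others in the source may bear on it.

Compound 1 `CN1CCN(C[C@H]2CN(c3ccc(-n4cc(-c5ccccn5)cn4)c(F)c3)C(=O)O2)CC1`: in an ADME assay on L02 cells (Homo sapiens) for cytotoxicity, read by MTT assay, with a stated time of 48 h (on this read-out higher numbers stand for weaker inhibition and lower numbers for stronger inhibition), compound 1 gives 70 ug/mL.
Compound 2 `O=C1O[C@@H](CN2CCCCC2)CN1c1ccc(-n2cc(-c3ccccn3)cn2)c(F)c1`: compound 2 reaches only a limit of the assay, > 400 ug/mL.
Compound 3 `O=C1O[C@@H](CSc2cccs2)CN1c1ccc(-n2cc(-c3ccccn3)cn2)c(F)c1`: compound 3 likewise reaches only a limit of the assay, > 400 ug/mL.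

Compound 3 therefore stands at the top of the numbers shown, where (the limit of > 400 ug/mL in this assay, at which 2 of the 3 values shown sit). Compound 4 `COC(=O)NC[C@H]1CN(c2ccc(-n3cc(-c4ccccn4)cn3)c(F)c2)C(=O)O1` keeps the shared core of compound 3 and changes one group: (methoxycarbonyl)amino in place of (thiophen-2-yl)sulfanyl on a saturated chain carbon bound to a saturated ring carbon. For the measured compounds named here, two measured steps bear on this position, an at least 5.7-fold higher number from compound 1 to compound 2 (0.75 log units; beyond the scatter) and an at least 5.7-fold higher number from compound 1 to compound 3 (0.75 log units; beyond the scatter), both moving away from compound 1 toward weaker inhibition; the step that the two limits leave unreadable from compound 2 to compound 3 gives no readable size. Compound 4 is therefore expected to stay at the limit, an expected step of a number no higher from compound 3 to compound 4 (the limit leaves the size open). The estimate for compound 4 is 400 ug/mL, within 150 ug/mL to 800 ug/mL.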

Compound 4, half-maximal inhibitory concentration: 71 ug/mL
Estimate against measurement, compound 4: 5.6-fold (0.75 log units) above, and the stated range ends above it.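

This position does not need 4-methylpiperazin-1-yl to give a measurable number in this assay: (methoxycarbonyl)amino, which has no ring, gives an at least 5.6-fold lower number from compound 3 to compound 4 (0.75 log units; beyond the scatter) and an at least 5.6-fold lower number from compound 2 to compound 4 (0.75 log units; beyond the scatter). Two quite different groups can therefore read alike here, with a 1.0-fold higher number from compound 1 to compound 4 (0.01 log units; within the scatter). Compound 2 and compound 3 remain limits, not numbers: the limit of > 400 ug/mL in this assay, at which 2 of the 4 values shown sit.

Which part of (methoxycarbonyl)amino matters stays open, and an acetylamino group would help to separate its parts. As far as these compounds go, whether a primary amine or a carboxylic acid on this chain carbon would read like compound 4 or like compound 2 also stays open.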